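Series notes: the methoxy to hydroxy step from compound 2

This account rests on a few compounds, and the source may have more. Where it says the series, first, only, none or still open, it means among the compounds named here.

Measured so far:
compound 1 `CC(=O)c1c(O)cc(O)c2c1OC(C)(C)CC2` — > 100000 nM
compound 2 `C=C1CC[C@H]2C(C)(C)CCC[C@]2(C)[C@H]1CC/C(C)=C/Cc1c(O)cc(O)c2c(=O)c(O)c(-c3ccc(OC)cc3)oc12` — > 100000 nM
compound 3 `CC(C)=CCC/C=C(\C)Cc1c(O)cc(O)c2c(=O)cc(-c3ccccc3)oc12` — 32000 nM

In a functional assay on HT-29 cells (Homo sapiens) for cytotoxicity, read by XTT assay, with a stated time of 72 h (a lower number here means a stronger inhibitor, a higher number a weaker inhibitor), compound 1 reaches only a limit, > 100000 nM. Compound 2 likewise gives only a limit in this assay, > 100000 nM. Within the data shown here, compound 3 is the one compound with a number in this assay, 32000 nM. Compound 2 therefore stands at the limit of > 100000 nM in this assay, at which 2 of the 3 values shown sit, with no number of its own to build on.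

Compound 4 `C=C1CC[C@H]2C(C)(C)CCC[C@]2(C)[C@H]1CC/C(C)=C/Cc1c(O)cc(O)c2c(=O)c(O)c(-c3ccc(O)cc3)oc12` is the next compound to be measured in this assay. It differs from compound 2 as follows: hydrogen in place of methyl on an oxygen on an aromatic ring

Among the measured compounds shown here, no measured pair differs in one place, so no measured step can be compared with this change. The step from compound 2 to compound 4 is expected to be small, with no direction beyond the scatter; the expected step is a number no higher from compound 2 to compound 4 (the limit leaves the size open). Compound 4 is expected to give about 100000 nM in this assay, within a range from 30000 nM to 300000 nM, and the assay is expected most likely to report only a limit again.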

Compound 4, half-maximal inhibitory concentration: 29000 nM
The estimate for compound 4 lay 3.4-fold (0.54 log units) above the measured number; measured number below the stated range.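

In this assay, among these compounds, hydrogen in place of methyl on the oxygen on the aromatic ring gives the first step that can be read, an at least 3.4-fold lower number from compound 2 to compound 4 (0.53 log units; beyond the scatter). With this change, compound 4 gives a measured number, 29000 nM. The chain shared with compound 2 therefore does not by itself hold a compound at the limit. The step gives a lower bound rather than a size, since the value of compound 2 is a limit and not a number: the limit of > 100000 nM in this assay, at which 2 of the 4 values shown sit.

On these data alone, the true size of the methoxy to hydroxy step stays open, and this single pair shows the change on one core only. As far as these compounds go, whether the free hydroxy is specifically required also stays open; an ethoxy group, an amine or a fluorine at the same place would test this.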